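This account rests on a few compounds, and the source may have more. Where it says the series, first, only, none or still open, it means among the compounds named here.

Measured in a functional assay on M21 cells (Homo sapiens) for antiproliferative activity, read by sulforhodamine B assay, with a stated time of 48 h; on this read-out lower numbers stand for stronger inhibition and higher numbers for weaker inhibition:
Compound 1 `COc1ccc(OS(=O)(=O)c2ccc(N3CCN(C)C3=O)cc2)cc1`: > 100000 nM, a limit
Compound 2 `CCCN1CCN(c2ccc(S(=O)(=O)Oc3ccccc3CC)cc2)C1=O`: > 50000 nM, a limit
Compound 3 `CCCN1CCN(c2ccc(S(=O)(=O)Oc3cccc(Cl)c3)cc2)C1=O`: 8600 nM

Compound 3, at 8600 nM, is the only one of the three with an actual number. The other two values are limits of the assay. Compound 4 `CCCN1CCN(c2ccc(S(=O)(=O)Oc3ccc(OC)cc3)cc2)C1=O` keeps the rest of compound 3 and changes one group: 4-methoxyphenyl in place of 3-chlorophenyl on an oxygen. Put simply, a 4-methoxyphenyl replaces the 3-chlorophenyl on an oxygen whose other neighbour is the sulfonyl sulfur.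

Within the data shown here, the one measured step at this place is an at least 5.8-fold lower number from compound 2 to compound 3 (0.76 log units; beyond the scatter). It shows that the group on this oxygen can move the result in this assay beyond the scatter. Compound 1 also carries the 4-methoxyphenyl, and its > 100000 nM is a limit. Compound 1 differs from compound 4 elsewhere as well, so it is only a loose guide. A modest step towards a higher number, meaning weaker inhibition, is therefore expected. The expected change is a 1.6-fold higher number from compound 3 to compound 4 (0.21 log units; within the scatter). For compound 4 the estimated value is 14000 nM, with an expected range from 3500 nM to 50000 nM.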

Compound 4, half-maximal inhibitory concentration: 23000 nM
Estimate against measurement, compound 4: 1.6-fold (0.22 log units) below, and the stated range covers the measured number.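

In this assay, a 2.7-fold higher number from compound 3 to compound 4 (0.43 log units; beyond the scatter) shows that 3-chlorophenyl and 4-methoxyphenyl on the oxygen bound to the sulfonyl sulfur can be told apart beyond the scatter, with compound 3 giving the lower number. Compound 4 nevertheless keeps a measurable number, and an at least 2.1-fold lower number from compound 2 to compound 4 (0.33 log units; beyond the scatter) rests on the limit of compound 2: the limit of > 50000 nM in this assay, at which 1 of the 4 values shown sits. A second place also affects the result, as an at least 4.3-fold lower number from compound 1 to compound 4 (0.63 log units; beyond the scatter) rests on the limit of compound 1: the limit of > 100000 nM in this assay, at which 1 of the 4 values shown sits.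

The step from compound 3 to compound 4 changes both the group on the ring and its printed position, so the compounds shown do not separate these two changes. As far as these compounds go, a 4-chlorophenyl or 3-methoxyphenyl on this oxygen would be needed to do so, and a longer chain on the amide-type nitrogen in a ring also remains open.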